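Swapping fluoro for chloro on an aryl methoxy neighbour

The source may hold more compounds than are shown below. What is called first, only, known or untested is meant among the compounds shown, and "the series" means these compounds.

Three compounds share one core and were tested in a functional assay on KYSE-450 cells (Homo sapiens) for inhibition, read by MTT assay, with a stated time of 48 h; a higher number here means a weaker inhibitor, a lower number a stronger inhibitor. Compound 1 `COc1ccc(CNc2cc(OC)c(OC)c(OC)c2)cc1` gives 4890 nM. Compound 2 `COc1ccc(CNc2cc(OC)c(OC)c(OC)c2)cc1[N+](=O)[O-]` gives 16800 nM, and compound 3 `COc1ccc(CNc2cc(OC)c(OC)c(OC)c2)cc1F` gives 46200 nM. Compound 3 therefore stands at the highest number of the three: the step of a 9.4-fold higher number from compound 1 to compound 3 (0.98 log units; beyond the scatter) is the largest gap, and the step of a 2.8-fold higher number from compound 2 to compound 3 (0.44 log units; beyond the scatter) is smaller but still beyond the scatter. Both steps touch the same aromatic carbon that is changed next.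

Compound 4 `COc1ccc(CNc2cc(OC)c(OC)c(OC)c2)cc1Cl` differs from compound 3 in one place: chloro in place of fluoro on an aromatic carbon. Among the compounds with values here, the steps that bear on this are those at the same carbon, a 9.4-fold higher number from compound 1 to compound 3 (0.98 log units; beyond the scatter) and a 2.8-fold higher number from compound 2 to compound 3 (0.44 log units; beyond the scatter), which show that what sits there shifts the number by modest amounts in either direction. Within the data shown here, no measured pair exchanges one halogen for another, so the direction of this step cannot be read from the data. The expectation is a small step in this assay, a 1.2-fold lower number from compound 3 to compound 4 (0.06 log units; within the scatter), close to the scatter. Compound 4 is therefore estimated at 40000 nM, within a range from 15000 nM to 110000 nM.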

Compound 4, half-maximal inhibitory concentration: 47800 nM
Compound 4: middle estimate off by 1.2-fold (0.08 log units), on the low side; low and high end bracket the measured number.
By their numbers in this assay, from the lowest: compound 1; then compound 2; then compounds 3 and 4 (each within the scatter of the next).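

In this assay, within the data shown here, this is the first exchange of one halogen for another at this aromatic carbon, and a 1.0-fold higher number from compound 3 to compound 4 (0.01 log units; within the scatter) stays within the scatter, so chloro and fluoro cannot be told apart here. Chloro also repeats the picture seen with fluoro, with a 2.8-fold higher number from compound 2 to compound 4 (0.45 log units; beyond the scatter) when it replaces nitro and a 9.8-fold higher number from compound 1 to compound 4 (0.99 log units; beyond the scatter) when it replaces hydrogen, so among the four groups compared at this carbon, hydrogen in compound 1 gives the strongest inhibitor, nitro in compound 2 comes next, and the two halogens share the weakest place. Nothing available explains why the two halogens behave alike in these cells, or why both give higher numbers than nitro and hydrogen.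

All three substituents shown at this carbon give a higher number than hydrogen, so it remains open whether a methyl, an amine or a hydroxyl group there would match compound 1 or improve on it. As far as these compounds go, it is also open whether the two halogens would stay alike if the methoxy group they sit ortho to gave way to a longer chain such as ethoxy.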